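Fixing the Cyclopropane Stereocentres of Compound 2

The compounds below may be only part of what the source reports. "The series", "measured", "known", "first", "only" and "open" are said of these compounds alone.

Compound 2 `CNC(=O)[C@]12C[C@@H]1[C@@H](n1cnc3c(NC4CC4c4ccc(F)c(F)c4)nc(C#Cc4cccc(F)c4)nc31)[C@H](O)[C@@H]2O` stands at a limit in an assay on isolated protein for binding affinity to adenosine receptor A3 (Homo sapiens); a higher number here means a weaker inhibitor, a lower number a stronger inhibitor: compound 2 gives >= 99 nM, a limit of the assay rather than a number. Compound 1 `CCOC(=O)[C@]12C[C@@H]1[C@@H](n1ccc3c(NCCCc4ccc(OC)c(O)c4)nc(C#Cc4ccccc4)nc31)[C@H](O)[C@@H]2O` likewise sits at a limit, and in this assay compound 1 gives >= 99 nM. Both values rest at the limit of >= 99 nM in this assay, at which 2 of the 2 values shown sit. Compound 3 `CNC(=O)[C@]12C[C@@H]1[C@@H](n1cnc3c(N[C@@H]4C[C@H]4c4ccc(F)c(F)c4)nc(C#Cc4cccc(F)c4)nc31)[C@H](O)[C@@H]2O` keeps every atom and bond of compound 2 and differs only in stereochemistry: the two compounds have the same atoms and bonds; at least one stereo element is drawn with a configuration in one of them and without one in the other: 2 of 7 stereo elements differ; a stereocentre at a saturated ring carbon is drawn without a configuration in compound 2 and R in compound 3; a stereocentre at a saturated ring carbon is drawn without a configuration in compound 2 and S in compound 3. Within the data shown here, no measured step of this kind exists here, so the step from compound 2 to compound 3 is expected to be small, a step that the limit leaves unreadable from compound 2 to compound 3, with little change beyond the scatter. Compound 3 is therefore expected to give 150 nM, within 40 nM to 600 nM.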

Compound 3, inhibition constant: >= 99 nM
Compound 3 gave a limit, no number (the forecaster's own chance of this, stated with the estimate: 60%); the middle value does not contradict the limit.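

Compound 2 and compound 3 both sit at a limit, so no step between them can be read: the limit of >= 99 nM in this assay, at which 3 of the 3 values shown sit.

The compounds shown leave open how strongly each one truly binds, and whether the defined configuration in compound 3 makes any difference.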